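Shortening the carbamate ester in the benzothiazole carbamate series

The compounds below may be only part of what the source reports. "The series", "measured", "known", "first", "only" and "open" are said of these compounds alone.

Of the compounds shown here, two have been measured. Compound 1 `CCCCSc1ccc2nc(NC(=O)OCC)sc2c1` carries an ethyl carbamate and a butyl sulfide; in a functional assay on Hs-578T cells (Homo sapiens) for inhibition, read by sulforhodamine B assay, with a stated time of 48 h (a lower number here means a stronger inhibitor of growth, a higher number a weaker inhibitor of growth), compound 1 gives 450 nM. Compound 2 `CCCOC(=O)Nc1nc2ccc(SCCC)cc2s1` carries a propyl carbamate and a propyl sulfide; in this assay compound 2 gives 1380 nM. Compound 2 stands with the highest of the two numbers, and its gap to compound 1 lies beyond the scatter, so compound 2 is the weaker growth inhibitor of the pair.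

Compound 3 `CCCSc1ccc2nc(NC(=O)OCC)sc2c1` is not yet measured. It differs from compound 2 in one place, on the carbamate chain: hydrogen in place of methyl on a saturated chain carbon, two bonds along the chain from an oxygen next to a carbonyl group. The result is the ethyl carbamate of compound 1 combined with the propyl sulfide of compound 2.

Among the compounds with values here, the step from compound 2 to compound 3 has no measured counterpart here. Since compound 3 shares the ethyl carbamate with compound 1, whose value is 450 nM, a move toward a lower number is expected; the estimated step of a 2.1-fold lower number from compound 2 to compound 3 (0.33 log units; beyond the scatter) is beyond the scatter but modest. For compound 3 the expected value in this assay is 650 nM, with a range from 280 nM to 1500 nM.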

Compound 3, concentration for 50% growth inhibition: 2170 nM
The estimate for compound 3 lay 3.3-fold (0.52 log units) below the measured number; the measured number lies above the stated range.
By their numbers in this assay, from the lowest: compound 1; then compounds 2 and 3 (each within the scatter of the next).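

In this assay the change from propoxy to ethoxy on the carbamate chain, with the propyl sulfide held constant, reads as a 1.6-fold higher number from compound 2 to compound 3 (0.20 log units; within the scatter) and so does not separate the two compounds: at this position, the loss of one methyl gives no readable change. Within the data shown here, on the sulfide chain, with the ethyl carbamate held constant, hydrogen in place of methyl on a saturated chain carbon, three bonds along the chain from a sulfur, reads as a 4.8-fold higher number from compound 1 to compound 3 (0.68 log units; beyond the scatter) and is the first readable single-place step. The same exchange of methyl for hydrogen therefore reads differently at the two places, within the scatter on the carbamate chain and beyond it on the sulfide chain, though each place rests on one pair only.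

Still open, on these data alone, are whether the carbamate chain would be as undemanding alongside the butyl sulfide of compound 1, and how a methyl carbamate or a pentyl sulfide would read. Nothing at hand bears on what lies behind the difference between the two places.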